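Swapping fluoro for chloro on the shared core

A few compounds are considered here, and "the series" means these few. Any claim that something is new, unique, unknown or untested is made for them only; others in the source may bear on it.

Measured compounds:
- compound 1, `COc1cc(C(=O)NC2CCN(C)CC2)ccc1Nc1ncc(Cl)c(NC2CCCC2)n1`: 4400 nM
- compound 2, `CN1CCC(NC(=O)c2ccc(Nc3ncc(F)c(NC4CCCC4)n3)cc2)CC1`: 16000 nM

Both compounds were tested in a functional assay on HCT-8 cells (Homo sapiens) for cytotoxicity, read by MTT assay, with a stated time of 48 h; on this read-out higher numbers stand for weaker inhibition and lower numbers for stronger inhibition. Compound 2 gives the highest number of the two, so on this read-out it is the weaker of the pair; its nearest neighbour is compound 1, whose number lies beyond the usual scatter, so the gap between them is real rather than noise.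

The unmeasured compound 3, `CN1CCC(NC(=O)c2ccc(Nc3ncc(Cl)c(NC4CCCC4)n3)cc2)CC1`, differs from compound 2 in one place: chloro in place of fluoro on an aromatic carbon. Within the data shown here, no step between two measured compounds isolates this exact exchange, so the size of the step cannot be read off directly. Still, compound 1 also carries chloro at the same position of the core and gives 4400 nM, a lower number than compound 2.

A modest step downward, toward stronger inhibition, is therefore expected, because compound 1 gives 4400 nM with the chloro in place; the step from compound 2 to compound 3 is estimated at a 2.5-fold lower number from compound 2 to compound 3 (0.39 log units; beyond the scatter). Compound 3 is estimated to give 6500 nM in this assay, within a range from 2500 nM to 16000 nM.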

Compound 3, half-maximal inhibitory concentration: 4600 nM
Compound 3: the middle estimate sits 1.4-fold (0.15 log units) above what was measured, within the range that was stated.
By their numbers in this assay, from the lowest: compounds 1 and 3 (each within the scatter of the next); then compound 2.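

In this assay, the exchange of fluoro for chloro on the aromatic carbon ortho to the cyclopentylamino group now has a measured size of its own, a 3.5-fold lower number from compound 2 to compound 3 (0.54 log units; beyond the scatter), on a core that otherwise stays the same. A second single change, hydrogen in place of methoxy on an aromatic carbon elsewhere in the molecule, gives a 1.0-fold higher number from compound 1 to compound 3 (0.02 log units; within the scatter), so with chloro in place this read-out cannot tell the compounds with and without the methoxy group apart, and of these two single changes only the halogen exchange moves the number beyond the scatter. Nothing among the data shown explains why this exchange changes the number.

On these data alone, only fluoro and chloro appear at this position, so it remains open how a bromo, methyl or nitrile group there would compare, and whether a plain hydrogen would give a higher or lower number than either halogen. As far as these compounds go, it also remains open whether the methoxy group would count for as little alongside fluoro as it does alongside chloro.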